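Imine series from the shared core: piperazinyl in place of imidazolylmethyl

This account rests on a few compounds, and the source may have more. Where it says the series, first, only, none or still open, it means among the compounds named here.

Three imines are in hand. Compound 1 `COc1cc(/C=N/CCCn2ccnc2)ccc1O`, compound 2 `COc1ccc(OC)c(/C=N/CC2CCCO2)c1` and compound 3 `COc1ccc(OC)c(/C=N/CCCn2ccnc2)c1` were all run in a functional assay on the whole organism (strain albino) for inhibition, with Rattus norvegicus as the target, read by paw edema, with stated times of 30 min and 3 h, at a dose of 50 mg/kg by the oral route; on this read-out lower numbers stand for less inhibition and higher numbers for more inhibition at the one dose given (going by the name of the read-out); in that test compound 1 gives 0%, compound 2 gives 16% and compound 3 gives 0%. Compound 3 is level with compound 1 at the digits shown, the two together at the bottom of the three numbers, and compound 2 sits higher than compound 3 by a gap beyond the scatter. The next compound, compound 4 `COc1ccc(OC)c(/C=N/CCN2CCNCC2)c1`, differs from compound 3 by piperazin-1-yl in place of (1H-imidazol-1-yl)methyl on a saturated chain carbon, two bonds along the chain from a double-bonded nitrogen. No step between measured compounds carries this change, so the direction rests on the spread shown. A small rise is expected, estimated as a number 10 percentage points higher from compound 3 to compound 4 (within the scatter) from compound 3 to compound 4. Compound 4 is estimated at 10%, between 0% and 30%.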

Compound 4, a percentage reported as inhibition, in the whole organism at one dose (the size of the read-out at that dose, not a potency): 21%
For compound 4 the middle estimate is 11 percentage points below the measured one, and the stated range covers the measured number.
By their numbers in this assay, from the lowest: compounds 1 and 3 (each within the scatter of the next); then compounds 2 and 4 (each within the scatter of the next).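

In this assay, for the compounds shown here, the change to piperazin-1-yl gives a number 21 percentage points higher from compound 3 to compound 4 (beyond the scatter) and is the first step, showing that this saturated chain carbon responds to the group it carries. The two groups match in heavy atoms, but the entering ring is non-aromatic and adds a hydrogen-bond donor. Nothing available explains the step. Open, from the compounds shown here alone, is whether the rise depends on the ring's free amine hydrogen, which 4-methylpiperazin-1-yl or morpholin-4-yl at this place would test. Going by these compounds, a longer chain carrying piperazin-1-yl also remains open.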